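Cytotoxicity of Nucleoside Analogues: From Indole to Hydroxyethyl Sulfide

The compounds below may be only part of what the source reports. "The series", "measured", "known", "first", "only" and "open" are said of these compounds alone.

Compound 1, `OC[C@H]1O[C@@H](n2cnc3c(Cn4ccc5ccccc54)ncnc32)[C@H](O)[C@@H]1O`: > 250000 nM
Compound 2, `OC[C@H]1O[C@@H](n2cnc3c(CSCc4ccccc4)ncnc32)[C@H](O)[C@@H]1O`: > 100000 nM

In a functional assay on Huh-7 cells (Homo sapiens) for cytotoxicity, read by MTT assay, with a stated time of 3 days (a higher number here means that more compound is tolerated, a lower number that less compound is tolerated), compound 1 stands only at a limit of the assay, > 250000 nM, not at a measured number. Compound 2 likewise shows only a limit, > 100000 nM. Both values are therefore limits, and the step between them stays unreadable: a step that the two limits leave unreadable from compound 1 to compound 2. The unmeasured compound 3, `OCCSCc1ncnc2c1ncn2[C@@H]1O[C@H](CO)[C@@H](O)[C@H]1O`, differs from compound 1 in one place: (2-hydroxyethyl)sulfanyl in place of 1H-indol-1-yl on a saturated chain carbon bound to an aromatic carbon. Going by the values given here, the only measured step at the same place is the one from compound 1 to compound 2, and it gives no size and no direction, since both of its values sit at limits. No step beyond the usual scatter is therefore expected in this assay; compound 3 is expected to stay at a limit as well, with an estimated step of a number no higher from compound 1 to compound 3 (the limit leaves the size open). Compound 3 is estimated at 250000 nM, with a range from 100000 nM to 1000000 nM.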

Compound 3, half-maximal cytotoxic concentration: > 100000 nM
Compound 3: a limit, no number; the forecaster's own chance of this, stated with the estimate: 85%; the middle value is on the limit's open side.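

In this assay, going by these compounds alone, compound 1, compound 2 and compound 3 all stand at limits rather than at numbers, so no step among them can be read. The compounds shown leave open what concentration of each would reach the half-maximal cytotoxic level, and whether the three groups differ at all.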